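The compounds below may be only part of what the source reports. "The series", "measured", "known", "first", "only" and "open" are said of these compounds alone.

Compound 1 `CCCCC[Se]c1nc(NCc2ccc(SC)cc2)c2ccccc2n1`: in a functional assay on CCRF-CEM cells (Homo sapiens) for cytotoxicity, read by MTT assay, with a stated time of 72 h (a lower number here means a stronger inhibitor of growth, a higher number a weaker inhibitor of growth), compound 1 gives 83900 nM.
Compound 2 `CCCCC[Se]c1nc([Se]CCCCC)c2ccccc2n1`: in this assay compound 2 reaches only the assay limit, > 100000 nM.
Compound 3 `Sc1nc(NCc2ccccc2)c2ccccc2n1`: in this assay compound 3 likewise reaches only the assay limit, > 100000 nM.

Compound 3 therefore stands at the edge of what the assay can report, the point where two of the three values sit (the limit of > 100000 nM in this assay, at which 2 of the 3 values shown sit), and no true number for it is known. Compound 4 `CCCCC[Se]c1nc(NCc2ccccc2)c2ccccc2n1` differs from compound 3 by a group of 6 heavy atoms (5 carbon, 1 selenium; no ring) in place of one sulfur atom, on an aromatic carbon. Within the data shown here, no measured pair shares this change, so its size has to be judged from neighbours. Compound 1 carries the same selenium-bearing group on the shared core and gives 83900 nM, a weak result. Compound 4 is expected to land near that, at 90000 nM, ranging from 30000 nM to 250000 nM. The expected step of an at least 1.1-fold lower number from compound 3 to compound 4 (0.04 log units; that floor lies within the scatter) is small, with a fair chance that only a limit is reported again.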

Compound 4, concentration for total growth inhibition: 72500 nM
Compound 4: the middle estimate sits 1.2-fold (0.09 log units) above what was measured; measured number inside the range.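

Putting the selenium-bearing group in place of the sulfanyl group, on the aromatic carbon between two ring nitrogen atoms, gives an at least 1.3-fold lower number from compound 3 to compound 4 (0.13 log units; that floor lies within the scatter), so a measured number now stands where there was only a limit. The change at the other end of compound 2 gives an at least 1.3-fold lower number from compound 2 to compound 4 (0.13 log units; that floor lies within the scatter), and both floors rest on a limit of the assay: the limit of > 100000 nM in this assay, at which 2 of the 4 values shown sit.

Methylsulfanyl on the benzyl ring makes no difference that stands out from the scatter: a 1.2-fold lower number from compound 1 to compound 4 (0.06 log units; within the scatter).

Still open, as far as these compounds go, is whether the same pentyl chain on sulfur, a longer chain, or an amine at this position would inhibit growth more strongly.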